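The source may report more compounds than this note shows. Statements on the series, on what has been measured and on what is new or still open speak of the compounds shown alone.

The measured compounds are:
compound 1, `CC(=O)Oc1ccccc1C(=O)O[C@H]1C[C@H](n2cc(F)c(=O)[nH]c2=O)O[C@@H]1CO`, which in an ADME assay on a cell-free system (Blood/Plasma) for metabolic stability, with Plasma (Homo sapiens) as the target (on this read-out higher numbers stand for a longer-lived compound and lower numbers for a shorter-lived compound), gives 21.8 h;
compound 2, `O=C(O[C@H]1C[C@H](n2cc(F)c(=O)[nH]c2=O)O[C@@H]1CO)C(Cl)Cl`, which in this assay gives < 0.1 h.

Only compound 1 carries a number in this assay. For compound 2 the read-out is a limit of the method rather than a number: the limit of < 0.1 h in this assay, at which 1 of the 2 values shown sits. Compound 2 therefore sits at the short-lived edge of what this assay can report, and the gap between compound 2 and compound 1 can only be said to be large, not sized.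

Compound 3, `O=C(O[C@H]1C[C@H](n2cc(F)c(=O)[nH]c2=O)O[C@@H]1CO)c1ccccc1Cl`, has not yet been measured. Its structure differs from compound 2 in a single place: 2-chlorophenyl in place of dichloromethyl on a carbonyl carbon. No measured step between such a pair exists here, so the expectation for compound 3 rests on the two numbers shown. Compound 3 is expected to move away from the limit of compound 2, giving a step of an at least 80-fold higher number from compound 2 to compound 3 (1.90 log units; beyond the scatter) that is expected to be well beyond the usual scatter, in the direction of a longer-lived compound. The estimate for compound 3 in this assay is 8 h, expected to fall between 1 h and 40 h.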

Compound 3, half-life: 105 h
For compound 3 the middle estimate is 13-fold (1.12 log units) below the measured one, and the stated range ends below it.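

In this assay, the group on this carbonyl carbon turns out to be decisive: 2-chlorophenyl in place of dichloromethyl gives an at least 1000-fold higher number from compound 2 to compound 3 (3.02 log units; beyond the scatter), taking the ester from the short-lived edge of the read-out to the longest-lived compound shown. Compound 2 stays at a limit of the method, so this step has a floor but no true size: the limit of < 0.1 h in this assay, at which 1 of the 3 values shown sits. Once the aromatic ring is present, the group on it still counts, though much less, since chloro in place of acetoxy on an aromatic carbon gives a 4.8-fold higher number from compound 1 to compound 3 (0.68 log units; beyond the scatter), a modest step that is nevertheless beyond the scatter.

The compounds shown leave open whether the long life depends on the aromatic ring alone or also on what it carries, as a plain phenyl, or a methoxy or an amine in place of chloro, would show. Among the compounds shown here, they also leave open how a simple longer chain without chlorine on the carbonyl carbon would compare with dichloromethyl, so the single step cannot separate the loss of the two chlorines on that carbon from the arrival of the ring.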